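A benzyl triazole replaces the diethylcarbamoyl group

The source may report more compounds than this note shows. Statements on the series, on what has been measured and on what is new or still open speak of the compounds shown alone.

In an ADME assay on HeLa cells (Homo sapiens) for cytotoxicity, read by MTT assay (a lower number here means a stronger inhibitor, a higher number a weaker inhibitor), compound 3 `CCN(CC)C(=O)COc1ccc(C[C@H]2C(=O)OC[C@@H]2Cc2ccc(OC)c(OC)c2)cc1OC` gives 188000 nM and stands level with the other two measured compounds. Compound 2 `COc1ccc(C[C@H]2COC(=O)[C@@H]2Cc2ccc(OCC(=O)Nc3ccc(C)cc3)c(OC)c2)cc1OC` gives 228000 nM in this assay and compound 1 `COc1ccc(C[C@H]2COC(=O)[C@@H]2Cc2ccc(OCc3cn(Cc4ccc(Cl)cc4)nn3)c(OC)c2)cc1OC` gives 242000 nM there, so all three values lie within the scatter of one another.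

The move to compound 4 `COc1ccc(C[C@H]2COC(=O)[C@@H]2Cc2ccc(OCc3cn(Cc4ccccc4)nn3)c(OC)c2)cc1OC` puts 1-benzyl-1H-1,2,3-triazol-4-yl in place of diethylcarbamoyl on a saturated chain carbon bound to an oxygen on an aromatic ring.

Among the measured compounds shown here, the one measured step that bears directly on this is a 1.2-fold lower number from compound 2 to compound 3 (0.08 log units; within the scatter) and it also exchanges a group on the same side chain, without leaving the scatter. For the measured compounds named here, compound 1 has no measured step to compound 4, yet the two differ only by a chlorine on the benzyl ring, which makes compound 1 at 242000 nM the closest guide available. Both observations point to little movement. The estimate amounts to a 1.2-fold higher number from compound 3 to compound 4 (0.07 log units; within the scatter) and thus no step beyond the scatter is expected in this assay here. Compound 4 is expected at 220000 nM (120000 nM to 400000 nM as the estimated range).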

Compound 4, half-maximal inhibitory concentration: 346000 nM
For compound 4 the middle estimate is 1.6-fold (0.20 log units) below the measured one, and the stated range covers the measured number.
By their numbers in this assay, from the lowest: compounds 3, 2, 1 and 4 (each within the scatter of the next).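

In this assay this position, on a saturated chain carbon bound to an oxygen on an aromatic ring, takes a much larger group without the number leaving the scatter: the change from diethylcarbamoyl, with 7 heavy atoms and no ring, to 1-benzyl-1H-1,2,3-triazol-4-yl, with 12 heavy atoms and two aromatic rings, gives a 1.8-fold higher number from compound 3 to compound 4 (0.26 log units; within the scatter) in this series. The same group in place of (4-methylphenyl)carbamoyl gives a 1.5-fold higher number from compound 2 to compound 4 (0.18 log units; within the scatter) so the two carbamoyl groups and the benzyl triazole cannot be told apart here, although only the triazole lacks the carbonyl. Within the triazole pair, hydrogen in place of chloro on an aromatic carbon gives a 1.4-fold higher number from compound 1 to compound 4 (0.16 log units; within the scatter) and this shows that the chlorine makes no readable difference on this benzyl ring.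

The compounds shown offer no evidence on why these numbers stay so close.

Going by these compounds, it remains open whether an amine, a carboxylic acid or a longer chain at this place would move the number beyond the scatter, and whether a fluorine or methoxy group on the benzyl ring would do so.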